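From Benzyl to Phenylcarbamoyl on the Ring Nitrogen

A few compounds are considered here, and "the series" means these few. Any claim that something is new, unique, unknown or untested is made for them only; others in the source may bear on it.

Compound 1 `COc1ccc(-c2cnc3nc(N)nc(N4CCN(c5ccc(F)cc5)CC4)c3n2)cc1OC` gives 100 nM in a functional assay on cells (T-cell, Homo sapiens) for inhibition; on this read-out higher numbers stand for weaker inhibition and lower numbers for stronger inhibition.
Compound 2 `COc1ccc(-c2cnc3nc(N)nc(N4CCN(Cc5c(Cl)cccc5Cl)CC4)c3n2)cc1OC` gives 7600 nM in this assay.
Compound 3 `COc1ccc(-c2cnc3nc(N)nc(N4CCN(Cc5ccccc5)CC4)c3n2)cc1OC` gives 900 nM in this assay.

Compound 3 stands second highest of the three numbers. Its nearest neighbour is compound 2, with an 8.4-fold lower number from compound 2 to compound 3 (0.93 log units; beyond the scatter); its furthest is compound 1, with a 9.0-fold higher number from compound 1 to compound 3 (0.95 log units; beyond the scatter). Compound 4 `COc1ccc(-c2cnc3nc(N)nc(N4CCN(C(=O)Nc5ccccc5)CC4)c3n2)cc1OC` differs from compound 3 in one place: phenylcarbamoyl in place of benzyl on an amine nitrogen in a ring.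

Within the data shown here, no measured step exchanges a benzyl for a phenylcarbamoyl, so the bearing steps are indirect. They show how much the group on this ring nitrogen moves the number: a 9.0-fold higher number from compound 1 to compound 3 (0.95 log units; beyond the scatter) and a 76-fold higher number from compound 1 to compound 2 (1.88 log units; beyond the scatter), and the second is clearly large. The shared core therefore tolerates some groups here far better than others, but none of the three measured groups carries a hydrogen-bond donor or acceptor, so nothing tells the direction for phenylcarbamoyl. The expectation for compound 4 is centred close to compound 3, with a wide range in both directions. Compound 4 is expected to give 1500 nM, within 250 nM to 9000 nM. This amounts to an expected step of a 1.7-fold higher number from compound 3 to compound 4 (0.22 log units; within the scatter), which in the middle lies within the scatter while admitting a real change either way.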

Compound 4, half-maximal inhibitory concentration: 3.4 nM
Beside the measured number, compound 4's estimate is 440-fold (2.64 log units) above it; measured number below the stated range.
By their numbers in this assay, from the lowest: compound 4; then compound 1; then compound 3; then compound 2.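

In this assay, the group on this ring nitrogen can do more than raise the number: phenylcarbamoyl gives a 29-fold lower number from compound 1 to compound 4 (1.47 log units; beyond the scatter), so 4-fluorophenyl no longer marks the low end of what this position allows. Measured against the groups with a saturated carbon on the ring nitrogen, the change is larger still, with a 260-fold lower number from compound 3 to compound 4 (2.42 log units; beyond the scatter) and a 2200-fold lower number from compound 2 to compound 4 (3.35 log units; beyond the scatter), so this single position spans a far wider range than the first three compounds suggested. Phenylcarbamoyl is also the only one of these groups that carries a hydrogen-bond donor and a hydrogen-bond acceptor, but this is only something the groups have in common with the result, and no measurement here explains why the number falls.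

The compounds shown leave open which part of phenylcarbamoyl matters: a benzoyl group, which keeps the carbonyl but has no amide hydrogen, would begin to separate the two. Also open, from the compounds shown here alone, is how much the phenyl ring contributes, which a methylcarbamoyl group on the same nitrogen would test.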